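The source may hold more compounds than are shown below. What is called first, only, known or untested is meant among the compounds shown, and "the series" means these compounds.

Two measured compounds set the scene. Compound 1 `c1ccc(COc2ccc(OCCOCCNc3ccncc3)cc2)cc1` carries a plain benzyl ether on its shared core and, in a functional assay on SK-OV-3 cells (Homo sapiens) for inhibition, read by CCK-8 assay, with a stated time of 70 h (on this read-out higher numbers stand for weaker inhibition and lower numbers for stronger inhibition), compound 1 gives 20600 nM. Compound 2 `O=C(O)c1ccccc1COc1ccc(OCCOCCNC2CCCC2)cc1` places a carboxy group on that outer ring and reaches no number at all: in this assay compound 2 gives only > 100000 nM, which is a limit of the assay rather than a measured value. So compound 2 stands at the top edge of what the assay can report, as noted by the limit of > 100000 nM in this assay, at which 1 of the 2 values shown sits, and its true potency can only be said to lie at or beyond that edge.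

Compound 3 `O=[N+]([O-])c1ccccc1COc1ccc(OCCOCCNC2CCCC2)cc1` is the next step. It differs from compound 2 in one place: nitro in place of carboxy on an aromatic carbon. The carboxy group that leaves is replaced by nitro on the same aromatic carbon, so the charge-neutral nitro now sits where the acid sat.

Since compound 2 starts at a limit, the step cannot be measured in full. The expected change is an at least 1.6-fold lower number from compound 2 to compound 3 (0.22 log units; that floor lies within the scatter), a move toward a measurable number, though still weak inhibition. Compound 3 is expected at about 60000 nM, within 20000 nM to 150000 nM.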

Compound 3, half-maximal inhibitory concentration: 5370 nM
For compound 3 the middle estimate is 11-fold (1.05 log units) above the measured one, and the stated range ends above it.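

In this assay, exchanging carboxy for nitro gives an at least 18-fold lower number from compound 2 to compound 3 (1.27 log units; beyond the scatter), so the group on this aromatic carbon, ortho to a large group, clearly matters for the read-out. Compound 2 gives > 100000 nM, and this is a limit of the assay rather than a number, whereas compound 3 provides the first measured value for this group of analogues with the cyclopentylamine-type side chain shown here. The step is therefore a floor and not a full size, because it starts from a compound at the edge of what the assay can report: the limit of > 100000 nM in this assay, at which 1 of the 3 values shown sits.

The compounds shown do not tell whether the lower number comes from losing the carboxy group or from gaining the nitro group itself. A methyl ester, an amine or a plain hydrogen on the same aromatic carbon could help separate those two readings, and a nitro group on another carbon of that ring could show how much depends on this particular place.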